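Propoxy in Place of Benzyloxyethoxy on the Shared Core

The source may report more compounds than this note shows. Statements on the series, on what has been measured and on what is new or still open speak of the compounds shown alone.

Compound 1 `COc1cc(C)c(-c2cccc(COc3ccc(OCC(=O)O)c(F)c3)c2)c(C)c1` sets the reference point: in a functional assay on CHO cells for agonist activity at Free fatty acid receptor 1 (Homo sapiens), read by FLIPR and calcium flux (on this read-out higher numbers stand for an effect only at larger amounts of compound and lower numbers for an effect already at smaller amounts), compound 1 gives 49.7 nM. Compound 2 `Cc1cc(OCCOCc2ccccc2)cc(C)c1-c1cccc(COc2ccc(OCC(=O)O)c(F)c2)c1` carries the same core but a longer ether chain, and in this assay compound 2 gives "not determined" (no result reported), so compound 2 stands nowhere on the numbers shown; it is known only as a structure. Compound 3 `CCCOc1cc(C)c(-c2cccc(COc3ccc(OCC(=O)O)c(F)c3)c2)c(C)c1` is reached from compound 2 by a single change: methyl in place of benzyloxy on a saturated chain carbon, two bonds along the chain from an oxygen on an aromatic ring. Among the compounds with values here, since compound 2 has no measured value, the size and direction of the step from compound 2 to compound 3 in this assay cannot be set against any number, and no step is available to guide it. What remains is the shorter chain of compound 3 on the same core, which is close to that of compound 1, and compound 1 with its value of 49.7 nM is the only anchor for an expectation. On that basis compound 3 is expected to land near compound 1 in this assay, with an estimate of 40 nM and a range from 12 nM to 130 nM.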

Compound 3, half-maximal effective concentration: 106 nM
Estimate against measurement, compound 3: 2.7-fold (0.42 log units) below; the measured number falls inside the stated range.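

In this assay, within the data shown here, ethyl in place of hydrogen on a saturated chain carbon bound to an oxygen on an aromatic ring gives a 2.1-fold higher number from compound 1 to compound 3 (0.33 log units; beyond the scatter), the first readable step at this position, showing that the longer propoxy chain is accompanied by a modest rise in the number, just beyond the usual scatter. The step from compound 2 to compound 3 cannot be read, as compound 2 has no number, so the exchange of 2-(benzyloxy)ethoxy for propoxy gives no measured effect and the ring-bearing chain remains unplaced relative to the two shorter ones. Nothing available accounts for the higher number of compound 3.

As far as these compounds go, two measured compounds give a single step and no trend, so it remains open whether a longer chain such as butoxy or pentyloxy would raise the number further or whether the change stops at propoxy. From the compounds shown here alone, it is equally open how this position would respond to a chain ending in an amine, a hydroxyl group or a carboxylic acid, or to a branched chain such as isopropoxy.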